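Swapping chloro for methyl on an inactive compound

The compounds below may be only part of what the source reports. "The series", "measured", "known", "first", "only" and "open" are said of these compounds alone.

Measured so far in a functional assay on A549 cells (Homo sapiens) for antiproliferative activity, read by MTT assay, with a stated time of 48 h; a lower number here means a stronger inhibitor, a higher number a weaker inhibitor
- Compound 1 `COc1ccc(-c2nc3cccc(-c4cc(OC)c(OC)c(OC)c4)c3o2)cc1OC` gives 2800 nM
- Compound 2 `COc1cc(-c2cccc3nc(-c4cccc(Cl)c4)oc23)cc(OC)c1OC` gives > 25000 nM (a limit, not a number)

Compound 2 has no exact value, and it sits at the end of the measurable range: the limit of > 25000 nM in this assay, at which 1 of the 2 values shown sits. Compound 3 `COc1cc(-c2cccc3nc(-c4cccc(C)c4)oc23)cc(OC)c1OC` differs from it by one substitution, (methyl in place of chloro on an aromatic carbon).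

Among the compounds with values here, only one measured step bears on this group. It is an at least 8.9-fold higher number from compound 1 to compound 2 (0.95 log units; beyond the scatter), and it lies beyond the scatter. That step shows that changing this aryl group can matter in this assay, but it replaced 3,4-dimethoxyphenyl, not a single small group, and its true size is open on one side. Within the data shown here, nothing measured so far covers methyl itself. A shift beyond the scatter is therefore not expected here, though a slight move towards a lower number is possible.

The expected change is small, with an at least 1.2-fold lower number from compound 2 to compound 3 (0.09 log units; that floor lies within the scatter) as the estimated step. Compound 3 is estimated at 20000 nM, with an expected range of 6000 nM to 40000 nM, and it may be reported only as a limit.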

Compound 3, half-maximal inhibitory concentration: 16700 nM
Compound 3: the middle estimate sits 1.2-fold (0.08 log units) above what was measured, within the range that was stated.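

Compound 2 counts only as a limit, not a number: the limit of > 25000 nM in this assay, at which 1 of the 3 values shown sits.

Compound 3 gives this aryl position a value that can be read exactly in this assay, so the cost of giving up the 3,4-dimethoxyphenyl group now has a firm size for one replacement: a 6.0-fold higher number from compound 1 to compound 3 (0.78 log units; beyond the scatter). Together with the earlier step from compound 1 to compound 2, this shows that the higher number is not tied to chloro, since the 3-chlorophenyl and 3-methylphenyl groups both lie beyond the scatter from compound 1. From the compounds shown here alone, the swap itself, an at least 1.4-fold lower number from compound 2 to compound 3 (0.17 log units; that floor lies within the scatter), has only a floor, and that floor lies within the scatter, so the real size of the change from chloro to methyl stays unknown and the two groups cannot be ranked.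

The compounds shown leave open whether a single methoxy group on this ring would be enough, or whether both methoxy groups of compound 1 are needed. They also do not tell how a hydroxyl group or an amine in place of the methyl would behave in this position.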